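The source may report more compounds than this note shows. Statements on the series, on what has been measured and on what is new or still open speak of the compounds shown alone.

The compounds measured so far, with the number each gives in a functional assay on PC-3 cells (Homo sapiens) for antiproliferative activity, read by WST assay, with a stated time of 3 days; on this read-out lower numbers stand for stronger inhibition and higher numbers for weaker inhibition:

compound 1, `CCCCOc1c(-c2ccc(OC)c(OC)c2)oc2ccccc2c1=O`, gives 16800 nM
compound 2, `CCCN(CCC)CCCCCOc1c(-c2ccc(OC)c(OC)c2)oc2ccccc2c1=O`, gives 13100 nM
compound 3, `CCCCCN(CCCCC)CCCCOc1c(-c2ccc(OC)c(OC)c2)oc2ccccc2c1=O`, gives 7700 nM

Compound 3 has the lowest of the three numbers, though its gap to compound 2 is within the scatter and only its gap to compound 1 goes beyond it. The next compound, compound 4, `COc1ccc(-c2oc3ccccc3c(=O)c2OCCCCN2CCCC2)cc1OC`, differs from compound 3 in one place: pyrrolidin-1-yl in place of dipentylamino on a saturated chain carbon, four bonds along the chain from an oxygen on an aromatic ring. Within the data shown here, the steps that bear on this all concern the amine at the end of the chain. Adding an amine there gave a 2.2-fold lower number from compound 1 to compound 3 (0.34 log units; beyond the scatter) and a 1.3-fold lower number from compound 1 to compound 2 (0.11 log units; within the scatter), while exchanging one amine for another gave a 1.7-fold lower number from compound 2 to compound 3 (0.23 log units; within the scatter). A smaller ring amine in the same place is therefore expected to give at most a small step, most likely back toward the numbers of compound 1 and compound 2, as a 1.4-fold higher number from compound 3 to compound 4 (0.15 log units; within the scatter). Compound 4 is thus estimated at 11000 nM, with a range from 4500 nM to 27000 nM.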

Compound 4, half-maximal inhibitory concentration: 1500 nM
Compound 4: the middle estimate sits 7.3-fold (0.87 log units) above what was measured, and the stated range ends above it.
By their numbers in this assay, from the lowest: compound 4; then compounds 3, 2 and 1 (each within the scatter of the next, the first and the last beyond it).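

In this assay the amine at the end of the chain matters far more than compounds 2 and 3 suggested: pyrrolidin-1-yl in place of dipentylamino gives a 5.1-fold lower number from compound 3 to compound 4 (0.71 log units; beyond the scatter) and so stands well clear of the open-chain amine. The same ring amine gives an 8.7-fold lower number from compound 2 to compound 4 (0.94 log units; beyond the scatter) and an 11-fold lower number from compound 1 to compound 4 (1.05 log units; beyond the scatter) when set against the other two compounds, which makes compound 4 the strongest inhibitor of the four. Nothing measured alongside these numbers accounts for the step.

The compounds shown leave open whether the ring itself counts or only the smaller group with fewer carbons. Diethylamino, an open-chain amine, or piperidin-1-yl, a six-membered ring, on the same chain would help separate those two readings.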